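Halogen and Methyl Swap on the Phenoxy Ring

The compounds below may be only part of what the source reports. "The series", "measured", "known", "first", "only" and "open" are said of these compounds alone.

Measured compounds:
compound 1 `S=C(N/N=C/c1ccc(Oc2ccc(Cl)cc2)cc1)Nc1ccc(Br)cc1` — 6.24
compound 2 `S=C(N/N=C/c1ccc(Oc2ccc(Br)cc2)cc1)Nc1ccc(Br)cc1` — 6.53

Compound 2 stands highest of the two numbers in a physicochemical assay for lipophilicity, in phosphate buffer, measured as octanol-water partition, with a stated time of 24 h (on this read-out lower numbers stand for lower lipophilicity and higher numbers for higher lipophilicity), with compound 1 within the scatter. Within the data shown here, the only measured step, a number 0.29 log units higher from compound 1 to compound 2 (within the scatter), covers the halogen exchange. Compound 3 `Cc1cc(Oc2ccc(/C=N/NC(=S)Nc3ccc(Br)cc3)cc2)ccc1Cl` carries 4-chloro-3-methylphenyl in place of 4-bromophenyl on an oxygen on an aromatic ring. Among the measured compounds shown here, that step reverses the halogen exchange and also adds a methyl group, for which no measured step exists, so no firm expectation beyond the scatter can be drawn. Compound 3 is expected at 6.6, between 6.2 and 7, the expected step being a number 0.07 log units higher from compound 2 to compound 3 (within the scatter).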

Compound 3, partition coefficient: 7.89
Estimate against measurement, compound 3: 1.29 log units below; measured number outside the range, above it.
By their numbers in this assay, from the lowest: compounds 1 and 2 (each within the scatter of the next); then compound 3.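

Where the halogen exchange stayed within the scatter in this assay, this position now gives a step beyond it: 4-chloro-3-methylphenyl in place of 4-bromophenyl on an oxygen on an aromatic ring gives a number 1.36 log units higher from compound 2 to compound 3 (beyond the scatter) as a large change. Methyl in place of hydrogen on an aromatic carbon, the one difference from the chloro compound, gives a number 1.65 log units higher from compound 1 to compound 3 (beyond the scatter) and is also large. Nothing available here accounts for these steps. As far as these compounds go, whether methyl would give a like step alongside bromo stays open, as does what an ethyl group, a methoxy group or an amine would give in its place.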